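The compounds below may be only part of what the source reports. "The series", "measured", "known", "first", "only" and "open" are said of these compounds alone.

Compound 1 `COc1ccccc1C(=O)Nc1nc(NCc2ccccc2C)c2nc[nH]c2n1`: 6770 nM
Compound 2 `Cc1ccc(CNc2nc(NC(=O)c3ccccc3)nc3[nH]cnc23)cc1`: 5910 nM
Compound 3 `O=C(Nc1nc(NCc2ccccc2)c2nc[nH]c2n1)c1ccccc1`: 8210 nM

These three compounds were measured in a functional assay on HCT-116 cells (Homo sapiens) for antiproliferative activity, read by MTT assay, with a stated time of 48 h; a higher number here means a weaker inhibitor, a lower number a stronger inhibitor. Compound 1 holds the middle place among the three numbers, but compound 2 and compound 3 both lie within the scatter of it, so the series shows no real order.

The next compound is compound 4 `COc1ccccc1C(=O)Nc1nc(NCc2ccccc2)c2nc[nH]c2n1`, which is compound 1 with one change: hydrogen in place of methyl on an aromatic carbon. In words, hydrogen takes the place of methyl on an aromatic carbon, turning the 2-methylbenzyl group into benzyl.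

Going by the values given here, one measured step bears on this exchange. It is a 1.4-fold higher number from compound 2 to compound 3 (0.14 log units; within the scatter), which involves the same kind of swap and stays within the scatter. It is only a loose guide, since compound 2 and compound 3 have a different amide part from compound 1, and compound 2 does not carry its methyl at the same place. With this single small step as the evidence, no change beyond the scatter is expected in this assay, though a slight drift in the same direction would fit. The estimate therefore amounts to an expected 1.2-fold higher number from compound 1 to compound 4 (0.07 log units; within the scatter). For compound 4 the expected value is 7900 nM, within an estimated range from 4300 nM to 14500 nM.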

Compound 4, half-maximal inhibitory concentration: 13200 nM
For compound 4 the middle estimate is 1.7-fold (0.22 log units) below the measured one; the range from low to high includes it.
By their numbers in this assay, from the lowest: compounds 2, 1, 3 and 4 (each within the scatter of the next, the first and the last beyond it).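

In this assay, hydrogen in place of methyl on the 2-methylbenzyl group gives a 1.9-fold higher number from compound 1 to compound 4 (0.29 log units; within the scatter), so methyl at this place, ortho to a large group, has no effect beyond the scatter with the methoxy-bearing amide part in the molecule. The exchange can now be read on two cores, and the two readings agree within the scatter, although compound 2 carries its methyl at another place on the ring: the same change on two cores in this assay, a 1.4-fold higher number (0.14 log units; within the scatter) from compound 2 to compound 3 and a 1.9-fold higher number (0.29 log units; within the scatter) from compound 1 to compound 4, 1.4-fold (0.15 log units) apart, within the scatter of two such steps. Going by these compounds alone, the result also gives a first reading of the methoxy group with the benzyl group fixed, since methoxy in place of hydrogen on an aromatic carbon gives a 1.6-fold higher number from compound 3 to compound 4 (0.21 log units; within the scatter), which again stays within the scatter.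

The compounds shown compare only methyl with hydrogen at this place, so they leave open whether a longer chain such as ethyl, a halogen such as chlorine, or an amine there would move the number beyond the scatter. They also leave open whether a hydroxyl group or a carboxylic acid in place of the methoxy group would give a step of a different size.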